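A few compounds are considered here, and "the series" means these few. Any claim that something is new, unique, unknown or untested is made for them only; others in the source may bear on it.

In a functional assay on KB cells (Homo sapiens) for cytotoxicity (a higher number here means that more compound is needed for the effect, a lower number that less compound is needed), compound 1 `CCOc1cc(-c2ccccc2)nc2ccccc12` gives 6.7 ug/mL, compound 2 `CC(C)Oc1cc(-c2ccccc2)nc2ccccc12` gives 4.2 ug/mL and compound 3 `CCCOc1cc(-c2ccccc2)nc2ccccc12` gives 4.5 ug/mL, so compound 3 stands within the scatter of both others. Compound 4 `CCCCOc1cc(-c2ccccc2)nc2ccccc12` turns propyl into butyl: methyl in place of hydrogen on a saturated chain carbon, three bonds along the chain from an oxygen on an aromatic ring. This places methyl in place of hydrogen on a saturated chain carbon, three bonds along the chain from an oxygen on an aromatic ring. The closest measured change, the same replacement two bonds along the chain from the oxygen, is a 1.5-fold lower number from compound 1 to compound 3 (0.17 log units; within the scatter). The other steps are a 1.6-fold lower number from compound 1 to compound 2 (0.20 log units; within the scatter) and a 1.1-fold higher number from compound 2 to compound 3 (0.03 log units; within the scatter). None leaves the scatter, so the expected result in this assay is no real shift, with the estimated change being a 1.1-fold lower number from compound 3 to compound 4 (0.03 log units; within the scatter). For compound 4 the estimated value is 4.2 ug/mL, with an expected range of 2.2 ug/mL to 8 ug/mL.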

Compound 4, half-maximal effective concentration: 3.8 ug/mL
Estimate against measurement, compound 4: 1.1-fold (0.04 log units) above, and the stated range covers the measured number.
By their numbers in this assay, from the lowest: compounds 4, 2, 3 and 1 (each within the scatter of the next).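

In this assay, butyl on the oxygen gives no real shift from any of the shorter or branched chains: a 1.2-fold lower number from compound 3 to compound 4 (0.07 log units; within the scatter), a 1.1-fold lower number from compound 2 to compound 4 (0.04 log units; within the scatter) and a 1.8-fold lower number from compound 1 to compound 4 (0.25 log units; within the scatter). Methyl in place of hydrogen three bonds along the chain from the oxygen thus leaves the number as flat as the same replacement closer to the oxygen. The replacement also reads alike in two settings: the same change on two cores in this assay, a 1.6-fold lower number (0.20 log units; within the scatter) from compound 1 to compound 2 and a 1.2-fold lower number (0.07 log units; within the scatter) from compound 3 to compound 4, 1.3-fold (0.13 log units) apart, within the scatter of two such steps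

On these data alone, whether a longer chain, or an amine or a carboxylic acid in place of butyl, would leave the scatter remains open. Changes elsewhere on the shared core also remain open.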